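The source may report more compounds than this note shows. Statements on the series, on what has been measured and on what is new or still open speak of the compounds shown alone.

Among the compounds with values here, in an ADME assay on microsomes (Homo sapiens) for metabolic stability (on this read-out higher numbers stand for a longer-lived compound and lower numbers for a shorter-lived compound), compound 1 `O=C(c1ccccc1)N1CCC(C(=O)N2N=CCC2c2ccccc2)CC1` gives 1.72 h as its half-life, the higher of the two actual numbers so far. Compound 3 `CC(C)(C)C(=O)N1N=CCC1c1cccc(Cl)c1` gives 0.138 h on the same read-out, a gap that lies beyond the usual scatter of repeated measurements. Compound 2 `CC(C)C(=O)N1N=CCC1c1ccccc1` is reported as > 1.5 h and that entry is a limit of the assay, not a number.

The unmeasured compound 4 `O=C(c1c[nH]nn1)N1CCC(C(=O)N2N=CCC2c2ccccc2)CC1` keeps the rest of compound 1 and changes one group, with 1H-1,2,3-triazol-4-yl in place of phenyl on a carbonyl carbon. Cut one bond further out, the same change reads benzoyl to (1H-1,2,3-triazol-4-yl)carbonyl. The counted difference is 1H-1,2,3-triazol-4-yl in place of phenyl on a carbonyl carbon and it is the whole of the change.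

Within the data shown here, no measured pair shows this swap, so the only anchor is compound 1 at 1.72 h and the expectation stays loose. The step expected is a 1.3-fold higher number from compound 1 to compound 4 (0.13 log units; within the scatter) and it stays within the scatter, so no real change is predicted in this assay for now. The result could also come back as a limit rather than a number. For compound 4 the estimate is 2.3 h with an expected range of 0.9 h to 6 h on repeat measurement.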

Compound 4, half-life: > 2.75 h
Compound 4 ended at the assay's limit (the forecaster's own chance of this, stated with the estimate: 35%); middle value at least 1.1-fold (0.07 log units) from the limit.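

In this assay compound 4 gives > 2.75 h, which is a limit of the assay and not a number: the limit of > 2.75 h in this assay, at which 1 of the 4 values shown sits.

Putting 1H-1,2,3-triazol-4-yl in place of phenyl on a carbonyl carbon gives an at least 1.5-fold higher number from compound 1 to compound 4 (0.20 log units; that floor lies within the scatter), so this step has a floor but no known size. Within the data shown here, the earlier compounds held no pair differing in one place, which makes this the first direct reading of any change at this position, and it shows that a five-membered aromatic ring with 3 hetero atoms can replace the six-membered ring of carbon only without the number falling in this assay.

The compounds shown leave open how far compound 4 really lies past its limit, so the true size of the step stays unknown. They also leave open whether the result follows the ring nitrogens or the hydrogen on nitrogen, a question that a methyl group on that triazole nitrogen or a pyridine ring on the same carbonyl carbon could help to separate.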